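This account rests on a few compounds, and the source may have more. Where it says the series, first, only, none or still open, it means among the compounds named here.

Of the compounds shown here, two have so far been tested in an ADME assay on Vero cells (Chlorocebus sabaeus) for cytotoxicity, read by MTT assay, with a stated time of 72 h; a higher number here means a weaker inhibitor, a lower number a stronger inhibitor. Compound 1, `CN(C)C(=O)C[C@H](CSc1ccccc1)Nc1c(C(=O)N/N=C/c2cccc(OC(F)(F)C(F)F)c2)cnc2c(C(F)(F)F)cccc12`, is one of them. In this assay compound 1 gives > 62.5 ug/mL, which is a limit of the assay rather than a number. Compound 2, `CN(C)C(=O)C[C@H](CSc1ccccc1)Nc1c(C(=O)N/N=C/c2ccccc2F)cnc2ccc(F)cc12`, is the other. In this assay compound 2 likewise gives > 62.5 ug/mL, again a limit and not a number. Compound 2 therefore stands where every measured value stands: the limit of > 62.5 ug/mL in this assay, at which 2 of the 2 values shown sit. Among the measured compounds shown here, no two measured compounds differ in only one place, so no step between measured values is known, and no pattern can be drawn from the pair.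

Compound 3, `CCCCCCCC/C=N/NC(=O)c1cnc2ccc(F)cc2c1N[C@@H](CSc1ccccc1)CC(=O)N(C)C`, is not yet measured. It differs from compound 2 in one place (octyl in place of 2-fluorophenyl on a carbon with a double bond to nitrogen). What leaves is one six-membered aromatic ring of carbon only; what enters has no ring. For the measured compounds named here, with no measured step to lean on, the expectation rests on where compound 2 sits. The step is expected to be a number no higher from compound 2 to compound 3 (the limit leaves the size open), that is none beyond the scatter, with the reading most likely staying at the limit. Compound 3 is expected to give about 62.5 ug/mL in this assay, within a range of 30 ug/mL to 125 ug/mL.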

Compound 3, half-maximal inhibitory concentration: > 62.5 ug/mL
Compound 3: a limit, no number; the forecaster's own chance of this, stated with the estimate: 60%; the middle value lies on the limit itself.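

Among the compounds shown here, compound 2 and compound 3 each give only a limit of the assay and not a number, so no step between them can be read in this assay. All the compounds shown share that reading: the limit of > 62.5 ug/mL in this assay, at which 3 of the 3 values shown sit.

Going by these compounds, what stays open is the actual value of each compound, and whether octyl and 2-fluorophenyl differ at all here.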